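This account rests on a few compounds, and the source may have more. Where it says the series, first, only, none or still open, it means among the compounds named here.

Measured so far:
compound 1, `CCC(C)(C)Cc1c[nH]c(CCc2ccc(-c3ccccc3C(=O)O)cc2)n1`: 94 nM
compound 2, `CCC(C)(C)Cc1c[nH]c(CCc2ccc(-c3ccc(F)cn3)cc2)n1`: 105 nM

Both numbers come from a functional assay on HEK293 cells for agonist activity at Bombesin receptor subtype-3 (Mus musculus), read by luminescence and calcium flux, with a stated time of 10 min; a lower number here means that less compound is needed, a higher number that more compound is needed for the effect. On these two numbers compound 2 stands as the higher, but only by a 1.1-fold higher number from compound 1 to compound 2 (0.05 log units; within the scatter), so the two values are not distinguishable from each other, and no order between compound 1 and compound 2 can be claimed.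

Compound 3, `CCC(C)(C)Cc1c[nH]c(CCc2ccc(-n3cncn3)cc2)n1`, has not been measured in this assay. Relative to compound 2 the change is 1H-1,2,4-triazol-1-yl in place of 5-fluoropyridin-2-yl on an aromatic carbon. Among the measured compounds shown here, the only measured step that touches the same position is the one from compound 1 to compound 2, where a 2-carboxyphenyl was exchanged for a 5-fluoropyridin-2-yl and the number moved by a 1.1-fold higher number from compound 1 to compound 2 (0.05 log units; within the scatter), inside the scatter. For the measured compounds named here, that step shows the position tolerates an exchange of the aromatic group without a clear shift, but the two groups tried so far were both six-membered; a five-membered ring with three hetero atoms has no precedent here.

On that basis the expected step in this assay for compound 3 is a 1.4-fold higher number from compound 2 to compound 3 (0.15 log units; within the scatter), a slight rise with wide uncertainty. Compound 3 is estimated at 150 nM, with a range from 40 nM to 600 nM.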

Compound 3, half-maximal effective concentration: 121 nM
Estimate against measurement, compound 3: 1.2-fold (0.09 log units) above; the measured number falls inside the stated range.
By their numbers in this assay, from the lowest: compounds 1, 2 and 3 (each within the scatter of the next).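

In this assay the 1H-1,2,4-triazol-1-yl group gives a 1.2-fold higher number from compound 2 to compound 3 (0.06 log units; within the scatter) against the 5-fluoropyridin-2-yl group, and a 1.3-fold higher number from compound 1 to compound 3 (0.11 log units; within the scatter) against the 2-carboxyphenyl group. The place on the aromatic carbon, para to a large group, therefore now accepts a five-membered aromatic ring with 3 hetero atoms as well as the two six-membered rings, with no separation among the three numbers, even though the triazole brings a smaller ring and more hydrogen-bond acceptors than the fluoropyridine it replaces. No independent data bear on this result, so the flat readout stays an observation without an explanation.

Going by these compounds, all three groups at this place are aromatic rings, so it remains open whether a non-aromatic group, such as an amine, a morpholine ring or a short alkyl chain, or a plain hydrogen would give a number in the same range. The rest of the shared core is identical across compounds 1, 2 and 3, which leaves open how far this tolerance holds with a different chain on the other side of the core.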